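Chloro for Methyl: From Compound 2 to Compound 3

A few compounds are considered here, and "the series" means these few. Any claim that something is new, unique, unknown or untested is made for them only; others in the source may bear on it.

Measured so far:
compound 1, `O=C(O)c1ccc(CSc2nc3cc(F)c(Oc4ccc(F)cc4)cc3[nH]2)cc1` — 900 nM
compound 2, `Cc1ccc(N/N=C2\C(=N)N(c3ccc(S(N)(=O)=O)cc3)N=C2N)cc1` — 1920 nM

In an assay on isolated protein for inhibition of Polyunsaturated fatty acid 5-lipoxygenase (Homo sapiens), read by colorimetric assay, with a stated time of 5 min (on this read-out lower numbers stand for stronger inhibition and higher numbers for weaker inhibition), compound 1 gives 900 nM. Compound 2 gives 1920 nM in this assay. Of the two numbers seen so far, compound 2 stands at the higher one; compound 1 sits at a lower number, and the gap between them is wider than repeat measurements alone would account for. For the measured compounds named here, the two compounds share no common core, so no single structural step connects them.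

Compound 3, `N=C1/C(=N\Nc2ccc(Cl)cc2)C(N)=NN1c1ccc(S(N)(=O)=O)cc1`, is not yet measured. It differs from compound 2 in one place: chloro in place of methyl on an aromatic carbon. Going by the values given here, no measured pair shows what such a swap does here, so the expectation rests on the change being small and leaving the rest of the molecule untouched. The step from compound 2 to compound 3 is therefore expected to stay within the usual scatter, as a 1.1-fold lower number from compound 2 to compound 3 (0.03 log units; within the scatter).

For compound 3 the value in this assay is estimated at 1800 nM, with a range from 700 nM to 4500 nM.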

Compound 3, half-maximal inhibitory concentration: 2310 nM
Compound 3: middle estimate off by 1.3-fold (0.11 log units), on the low side; the measured number falls inside the stated range.
By their numbers in this assay, from the lowest: compound 1; then compounds 2 and 3 (each within the scatter of the next).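

For the compounds shown here, the step from methyl to chloro on the aromatic carbon para to a large group is the first single-place comparison available here. In this assay, it amounts to a 1.2-fold higher number from compound 2 to compound 3 (0.08 log units; within the scatter), so this pair gives no sign that inhibition distinguishes 4-methylphenyl from 4-chlorophenyl at this position. The swap can therefore be made here without a readable change in this measurement, although no supporting measurement is available to explain that result.

The compounds shown leave open how this position would respond to a group of a different kind, such as an amine, a carboxylic acid or a longer alkyl chain. They also leave open whether chloro in place of methyl would read the same way on a different core, such as that of compound 1.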